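Adding Methoxy to the Side Chain of Compound 3

This account rests on a few compounds, and the source may have more. Where it says the series, first, only, none or still open, it means among the compounds named here.

Compound 3 (`COc1ccc(/C=C/CCCOc2cc(/C=C\c3cc(OC)c(OC)c(OC)c3)ccc2OC)cc1`) stands at 88000 nM in an ADME assay on HEK293 cells (Homo sapiens) for inhibition, read by MTT assay, with a stated time of 3 days; a lower number here means a stronger inhibitor, a higher number a weaker inhibitor. Compound 1 (`C=CCOc1cc(/C=C\c2cc(OC)c(OC)c(OC)c2)ccc1OC`) gives 43500 nM and compound 2 (`COc1ccc(/C=C\c2cc(OC)c(OC)c(OC)c2)cc1OCc1ccc(Br)cc1`) gives 45000 nM. Compound 4 (`COCOc1ccc(/C=C/CCCOc2cc(/C=C\c3cc(OC)c(OC)c(OC)c3)ccc2OC)cc1`) differs from compound 3 by a single change, methoxy in place of hydrogen on a saturated chain carbon bound to an oxygen on an aromatic ring, which turns 4-methoxyphenyl into 4-(methoxymethoxy)phenyl.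

Going by the values given here, no measured step covers this exact change. The closest evidence comes from the three exchanges of side-chain groups at one shared place. These show a 1.0-fold higher number from compound 1 to compound 2 (0.01 log units; within the scatter), then a 2.0-fold higher number from compound 1 to compound 3 (0.31 log units; beyond the scatter), and finally a 2.0-fold higher number from compound 2 to compound 3 (0.29 log units; within the scatter). Even these whole-group exchanges moved the number only modestly or not beyond the scatter, so no step beyond the scatter is expected in this assay for the smaller addition here. The expected result is a 1.1-fold lower number from compound 3 to compound 4 (0.04 log units; within the scatter). Compound 4 is estimated at 80000 nM, with an expected range of 40000 nM to 160000 nM.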

Compound 4, half-maximal inhibitory concentration: 25000 nM
Compound 4: middle estimate off by 3.2-fold (0.51 log units), on the high side; the whole stated range lies above it.
By their numbers in this assay, from the lowest: compounds 4, 1, 2 and 3 (each within the scatter of the next, the first and the last beyond it).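

In this assay, methoxy in place of hydrogen on a saturated chain carbon bound to an oxygen on an aromatic ring gives a 3.5-fold lower number from compound 3 to compound 4 (0.55 log units; beyond the scatter), so the number responds to this small addition. The earlier steps shown here were exchanges of whole groups, and they did not show that a change this small, turning 4-methoxyphenyl into 4-(methoxymethoxy)phenyl, could move the number beyond the scatter. Nothing shown here accounts for the step.

The compounds shown leave open whether the added oxygen, the added carbon or the whole methoxymethoxy group carries the step. A hydroxyl, an ethoxymethoxy chain or an amine in the same place would separate these readings, and a single pair cannot say whether the step would recur on another side chain.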